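The compounds below may be only part of what the source reports. "The series", "measured", "known", "first", "only" and "open" are said of these compounds alone.

Compound 1 `CNc1nc(NCc2ccc(NC(=O)c3ccc(Cl)nc3)cc2)c2ccccc2n1`: 0.283 h
Compound 2 `CNc1nc(NCc2ccc(NC(=O)c3ccc(C)cc3)cc2)c2ccccc2n1`: 0.267 h

For the measured compounds named here, in an in vitro ADME assay on microsomes from liver (Rattus norvegicus) for metabolic stability (on this read-out lower numbers stand for a shorter-lived compound and higher numbers for a longer-lived compound), compound 1 stands level with the only other measured compound, as the data show a 1.1-fold lower number from compound 1 to compound 2 (0.03 log units; within the scatter). Compound 3 `CNc1nc(NCc2ccc(NC(=O)c3ccc(Cl)nc3)cc2)c2cc(C)ccc2n1` keeps the rest of compound 1 and changes one place: methyl in place of hydrogen on an aromatic carbon. Going by the values given here, the one measured step put 4-methylphenyl in place of 6-chloropyridin-3-yl on a carbonyl carbon, so it is only a weak guide to this different place. With so little evidence, the expected change is a 1.1-fold lower number from compound 1 to compound 3 (0.04 log units; within the scatter), none beyond the scatter. For compound 3 the estimate is 0.26 h, with an expected range of 0.14 h to 0.45 h.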

Compound 3, half-life: 0.217 h
Compound 3: middle estimate off by 1.2-fold (0.08 log units), on the high side; low and high end bracket the measured number.
By their numbers in this assay, from the lowest: compounds 3, 2 and 1 (each within the scatter of the next).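

In this assay, for the compounds shown here, the shared core is changed for the first time on its six-membered aromatic ring of carbon only: methyl in place of hydrogen on an aromatic carbon gives a 1.3-fold lower number from compound 1 to compound 3 (0.12 log units; within the scatter), so the added methyl leaves the half-life level with that of compound 1. No available evidence bears on this small step. Still open, from the compounds shown here alone, is whether a larger group at this place, such as methoxy, an amine or a carboxylic acid, would move the number beyond the scatter. Also open, going by these compounds, is whether methyl here would behave alike on compound 2.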